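From two fluorines to one chlorine on the ring

This account rests on a few compounds, and the source may have more. Where it says the series, first, only, none or still open, it means among the compounds named here.

Among the compounds with values here, in an ADME assay for protein binding, using equilibrium dialysis, at pH 7.4, tested at 2 uM (on this read-out higher numbers stand for a larger free fraction and lower numbers for a smaller free fraction), compound 2 `CC(C)N(C(=O)C1CCC(F)(F)CC1)c1cc(C#CC(C)(C)C)sc1C(=O)O` gives 0.4, the higher of the two numbers measured so far. Within the data shown here, the only comparison available is compound 1 `CC(C)N(C(=O)C1CCCCC1)c1cc(C#CC(C)(C)C)sc1C(=O)O`, which gives 0.18. Compound 3 `CC(C)N(c1cc(C#CC(C)(C)C)sc1C(=O)O)C(=O)[C@H]1CC[C@H](Cl)CC1` has not been measured yet and differs from compound 2 at one place, on a carbonyl carbon: 4-chlorocyclohexyl in place of 4,4-difluorocyclohexyl on a carbonyl carbon.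

Among the measured compounds shown here, one measured step bears on this change. It is a 2.2-fold higher number from compound 1 to compound 2 (0.35 log units; beyond the scatter), a modest step beyond the scatter, seen when 4,4-difluorocyclohexyl took the place of cyclohexyl. For the measured compounds named here, no compound with 4-chlorocyclohexyl has been measured, so this single step is weak guidance. Compound 3 no longer carries the fluorine atoms that distinguish compound 2 from compound 1, so a return towards the lower number of compound 1 seems the likeliest outcome. The expected change is a modest fall, a 1.8-fold lower number from compound 2 to compound 3 (0.26 log units; within the scatter). In this assay compound 3 is expected to give about 0.22, with an estimated range from 0.12 to 0.38.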

Compound 3, unbound fraction: 0.14
Compound 3: the middle estimate sits 1.6-fold (0.20 log units) above what was measured; measured number inside the range.
By their numbers in this assay, from the lowest: compounds 3 and 1 (each within the scatter of the next); then compound 2.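

Replacing the two fluorines with one chlorine does not keep the higher free fraction in this assay: the change gives a 2.9-fold lower number from compound 2 to compound 3 (0.46 log units; beyond the scatter) and goes beyond the usual scatter. Measured against the unsubstituted cyclohexyl, chloro in place of hydrogen on a saturated ring carbon gives a 1.3-fold lower number from compound 1 to compound 3 (0.11 log units; within the scatter), which stays within the scatter, so these two compounds cannot be told apart here. At this position, then, a substituent on the ring does not by itself separate a compound from the plain cyclohexyl: among the three compounds, only the 4,4-difluorocyclohexyl of compound 2 stands apart, and nothing measured here explains this difference between the fluorines and the chlorine.

Going by these compounds, whether the higher number needs both fluorines remains open, and a 4-fluorocyclohexyl group, with a single fluorine on the ring, would address that directly. Also open, on these data alone, is whether the result for 4-chlorocyclohexyl holds for its other stereoisomer, or for a 4,4-dichlorocyclohexyl group, which would set two chlorines against the two fluorines of compound 2.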